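The compounds below may be only part of what the source reports. "The series", "measured", "known", "first", "only" and "open" are said of these compounds alone.

Working notes on the series, step from compound 2 to compound 4.

Compound 2 `N=C(N)NCCC[C@H](NC(=O)CN(c1nc(Cl)nc2[nH]cnc12)C1CC1)C(=O)O` is the free acid of this group. In a functional assay on the whole organism (Tail, strain ICR) with Mus musculus as the target, in the tail flick test, with a stated time of 60 min, at a dose of 25 umol/kg by the oral route (a higher number here means a stronger effect of the compound at the dose given, a lower number a weaker effect), compound 2 gives 51%, the highest of the three numbers in hand. Among the measured compounds shown here, its benzyl ester, compound 3 `N=C(N)NCCC[C@H](NC(=O)CN(c1nc(Cl)nc2[nH]cnc12)C1CC1)C(=O)OCc1ccccc1`, gives 30.6% in this assay; the step of a number 20.4 percentage points lower from compound 2 to compound 3 (beyond the scatter) is the only single-point comparison measured. For the measured compounds named here, compound 1 `NC(=O)CC[C@H](NC(=O)CN(c1ncnc2c1ncn2C1CCCCO1)C1CC1)C(=O)OCc1ccccc1`, a benzyl ester on a different core and a different side chain, gives 39.4% in this assay, and its two values alongside compound 2 show it standing lower, though no single step links them.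

Compound 4 `O=C(O)CC[C@H](NC(=O)CN(c1nc(Cl)nc2[nH]cnc12)C1CC1)C(=O)O` differs from compound 2 by a group of 3 heavy atoms (1 carbon, 2 oxygen; no ring) in place of a group of 5 heavy atoms (2 carbon, 3 nitrogen; no ring), on a saturated chain carbon, three bonds along the chain from an amide-type nitrogen and a carbonyl carbon. Going by the values given here, no measured step bears on this side-chain exchange: the one step in hand concerns the oxygen of the carbonyl group, which compound 4 keeps as in compound 2. The direction is therefore open, and any step beyond the scatter is a guess either way. The expectation for compound 4 in this assay is 40%, with a range of 18% to 62%, which is expected to mean a step of a number 11 percentage points lower from compound 2 to compound 4 (beyond the scatter).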

Compound 4, a percentage reported as activity, at one dose (the size of the read-out at that dose, not a potency): 33.3%
Compound 4: middle estimate off by 6.7 percentage points, on the high side, within the range that was stated.
By their numbers in this assay, from the lowest: compounds 3, 4 and 1 (each within the scatter of the next); then compound 2.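

The side-chain position, on a saturated chain carbon, three bonds along the chain from an amide-type nitrogen and a carbonyl carbon, now carries a measured change: in this assay, carboxy in place of the group of 5 heavy atoms (2 carbon, 3 nitrogen; no ring) gives a number 17.7 percentage points lower from compound 2 to compound 4 (beyond the scatter). Among the compounds shown here, the read-out therefore responds to this side chain as well as to the benzyl ester, for which a number 20.4 percentage points lower from compound 2 to compound 3 (beyond the scatter) was the only step in hand. No available evidence bears on the reason for this step.

As far as these compounds go, whether a primary amine at this position, or a longer chain ending in the carboxylic acid, would keep the read-out near that of compound 2 remains open. Also open, from the compounds shown here alone, is how a benzyl ester would act on the carboxy side chain of compound 4.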